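The compounds below may be only part of what the source reports. "The series", "measured", "known", "first", "only" and "open" are said of these compounds alone.

Three measured compounds share one core and differ only in the group attached to a triple-bonded carbon. Compound 1 `CNC(=O)[C@@]12C[C@@H]1[C@@H](n1cnc3c(NC)nc(C#Cc4ccc(OC)cc4)nc31)[C@H](O)[C@@H]2O` carries a 4-methoxyphenyl group there and gives 0.63 nM in an assay on CHO cells for displacement of a labelled ligand from adenosine receptor A3 (Homo sapiens), read by scintillation counting, with a stated time of 60 min; a lower number here means a stronger inhibitor, a higher number a weaker inhibitor. Compound 2 `CNC(=O)[C@@]12C[C@@H]1[C@@H](n1cnc3c(NC)nc(C#Cc4ncccn4)nc31)[C@H](O)[C@@H]2O` carries a pyrimidin-2-yl group and gives 1.97 nM in this assay. Compound 3 `CNC(=O)[C@@]12C[C@@H]1[C@@H](n1cnc3c(NC)nc(C#Cc4cnn(C)c4)nc31)[C@H](O)[C@@H]2O` carries a 1-methyl-1H-pyrazol-4-yl group and gives 2.34 nM in this assay, the highest of the three numbers; its gap to compound 2 is within the scatter, while compound 1 sits well below it.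

Compound 4 `CNC(=O)[C@@]12C[C@@H]1[C@@H](n1cnc3c(NC)nc(C#Cc4cc5ccccc5o4)nc31)[C@H](O)[C@@H]2O` is not yet measured. The change is 1-benzofuran-2-yl in place of 1-methyl-1H-pyrazol-4-yl on a triple-bonded carbon. The measured steps show that swapping the group on the triple-bonded carbon shifts the number by modest amounts: a 3.1-fold higher number from compound 1 to compound 2 (0.50 log units; beyond the scatter), a 3.7-fold higher number from compound 1 to compound 3 (0.57 log units; beyond the scatter), and a 1.2-fold higher number from compound 2 to compound 3 (0.07 log units; within the scatter). Moving from the five-membered ring with 2 hetero atoms toward a larger group with a six-membered aromatic ring of carbon only resembles the direction of compound 1, which gave the lowest number. The step from compound 3 to compound 4 is therefore expected to lower the number modestly, a 2.9-fold lower number from compound 3 to compound 4 (0.47 log units; beyond the scatter). Compound 4 is estimated at 0.8 nM, with a range from 0.25 nM to 2.5 nM.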

Compound 4, inhibition constant: 1.62 nM
Estimate against measurement, compound 4: 2.0-fold (0.31 log units) below; low and high end bracket the measured number.
By their numbers in this assay, from the lowest: compound 1; then compounds 4, 2 and 3 (each within the scatter of the next).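

In this assay, a second ring on the triple-bonded carbon does not by itself set the new group apart: putting 1-benzofuran-2-yl in place of 1-methyl-1H-pyrazol-4-yl gives a 1.4-fold lower number from compound 3 to compound 4 (0.16 log units; within the scatter) and putting it in place of pyrimidin-2-yl gives a 1.2-fold lower number from compound 2 to compound 4 (0.08 log units; within the scatter) in the same assay. These three groups differ in their rings and hetero atoms, yet the assay cannot separate them, while the step from the 4-methoxyphenyl group remains beyond the scatter, at a 2.6-fold higher number from compound 1 to compound 4 (0.41 log units; beyond the scatter) for the new group. Nothing measured here explains why the 4-methoxyphenyl group stands apart from the other three.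

Every group shown at this position is built on aromatic rings, so the effect of an amine, a carboxylic acid or a longer carbon chain on the triple-bonded carbon remains open. From the compounds shown here alone, a plain phenyl group would help show whether the methoxy group or the carbon-only ring goes with the separate value of the 4-methoxyphenyl compound, and that question also remains open.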